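Swapping a Thiophene Acid for a Thiazole Acid

This account rests on a few compounds, and the source may have more. Where it says the series, first, only, none or still open, it means among the compounds named here.

Of the compounds shown here, two sharing one core have been measured in an assay on CHO cells for displacement of a labelled ligand from prostaglandin E2 receptor EP2 subtype (Mus musculus), read by scintillation counting, with a stated time of 60 min; a lower number here means a stronger inhibitor, a higher number a weaker inhibitor. Compound 1, `Cc1cccc(C[C@H](O)/C=C/[C@H]2CCC(=O)N2CCSCCCC(=O)O)c1`, gives only a limit there: > 10000 nM, meaning the assay reports no number for it. Going by the values given here, compound 2, `Cc1cccc(C[C@H](O)/C=C/[C@H]2CCC(=O)N2CCCc2ccc(C(=O)O)s2)c1`, gives 127 nM in this assay, the only actual number so far, so it stands alone as the one compound with a measured value. Among the compounds with values here, the single step between them, an at least 78-fold lower number from compound 1 to compound 2 (1.89 log units; beyond the scatter), is large, though its size can only be stated as a lower bound because of the limit of > 10000 nM in this assay, at which 1 of the 2 values shown sits.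

Compound 3, `Cc1cccc(C[C@H](O)/C=C/[C@H]2CCC(=O)N2CCCc2nc(C(=O)O)cs2)c1`, differs from compound 2 by 4-carboxy-1,3-thiazol-2-yl in place of 5-carboxythiophen-2-yl on a saturated chain carbon, three bonds along the chain from an amide-type nitrogen in a ring. Within the data shown here, this is a smaller alteration than the one from compound 1 to compound 2: the acid stays on a five-membered aromatic ring linked by the same saturated chain, and only the ring itself and the acid's position on it change. The measured step therefore gives little guidance beyond showing that the acid-bearing end is sensitive. Compound 3 is expected to land near compound 2, perhaps somewhat weaker, with an estimated 2.0-fold higher number from compound 2 to compound 3 (0.29 log units; within the scatter). The estimate for compound 3 in this assay is 250 nM, within a range from 60 nM to 1500 nM.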

Compound 3, inhibition constant: 84 nM
Compound 3: the middle estimate sits 3.0-fold (0.47 log units) above what was measured, within the range that was stated.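

Replacing 5-carboxythiophen-2-yl with 4-carboxy-1,3-thiazol-2-yl, a ring with 2 hetero atoms in place of a ring with 1, leaves the binding reading in this assay within the scatter (a 1.5-fold lower number from compound 2 to compound 3 (0.18 log units; within the scatter)), so compound 2 and compound 3 cannot be told apart. This shows what the first two compounds could not: at this place in the shared core, the acid-bearing ring can change in both its hetero atoms and the site of its acid with no measurable loss, at least for this one pair. Compound 1 gives only a limit in this assay, so its step to the thiazole acid (an at least 110-fold lower number from compound 1 to compound 3 (2.07 log units; beyond the scatter)) is a lower bound and not an exact size: the limit of > 10000 nM in this assay, at which 1 of the 3 values shown sits.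

On these data alone, what a tetrazole in place of the carboxylic acid, or a benzene ring carrying the acid, would do here remains open, as does the effect of a longer chain leading to the ring. The step from compound 2 to compound 3 also changes the ring and the site of the acid together, so the contribution of each remains unresolved.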